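From sec-butyl to cyclopentyl on a sulfur

A few compounds are considered here, and "the series" means these few. Any claim that something is new, unique, unknown or untested is made for them only; others in the source may bear on it.

In an ADME assay on MT4 cells (Homo sapiens) for activation, read by MTT assay (a higher number here means that more compound is tolerated, a lower number that less compound is tolerated), compound 3 `CCc1c(C(C)c2c(F)cccc2Cl)nc(SC(C)CC)[nH]c1=O` reads > 3000 nM, which is a limit. Compound 1 `CC(c1cc(=O)[nH]c(SC2CCCC2)n1)c1c(F)cccc1Cl` reads > 71000 nM, also a limit. Compound 2 `Cc1c(C(C)c2c(F)cccc2Cl)nc(SC2CCCC2)[nH]c1=O` reads > 15000 nM, again a limit. None of the three values shown is therefore an exact number. Compound 4 `CCc1c(C(C)c2c(F)cccc2Cl)nc(SC2CCCC2)[nH]c1=O` differs from compound 3 by cyclopentyl in place of sec-butyl on a sulfur, with cyclopentyl in place of sec-butyl on a sulfur. Going by the values given here, the only measured step, a step that the two limits leave unreadable from compound 1 to compound 2, concerns a different change and offers no size to carry over. Compound 2 already carries cyclopentyl on a sulfur, and its limit of > 15000 nM suggests that the group is well tolerated. The estimated step, taken from a limit, is a step that the limit leaves unreadable from compound 3 to compound 4, towards more compound tolerated. For compound 4 the expected value is 15000 nM, with an estimated range of 3000 nM to 70000 nM.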

Compound 4, half-maximal cytotoxic concentration: > 3000 nM
Compound 4 gave a limit, no number; the forecaster's own chance of this, stated with the estimate: 85%; the middle value does not contradict the limit.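

Compound 4 gives > 3000 nM, a limit. Going by these compounds alone, compound 1, compound 2 and compound 3 also stand only as limits, so no step to compound 4 can be read. The compounds shown leave open whether cyclopentyl and sec-butyl on a sulfur differ at all in this assay.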